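The source may hold more compounds than are shown below. What is called first, only, known or untested is meant among the compounds shown, and "the series" means these compounds.

Measured compounds:
- compound 1, `CC1CCN(c2nc(Cl)nc3c2ncn3Cc2ccc(/C=C/C(=O)Nc3ccccc3N)cc2)CC1`, in a functional assay on NCI-H460 cells (Homo sapiens) for antiproliferative activity, read by CCK-8 assay, with a stated time of 72 h, tested at 2 uM (a higher number here means a stronger effect of the compound at the concentration tested, a lower number a weaker effect), gives 8.24%
- compound 2, `Nc1ccccc1NC(=O)/C=C/c1ccc(Cn2cnc3c(Nc4cccc(OC(F)(F)F)c4)nc(Cl)nc32)cc1`, in this assay gives 2.1%

Among the compounds with values here, compound 1 stands highest of the two numbers in this assay, with compound 2 nearest to it; the one recorded step, a number 6.1 percentage points lower from compound 1 to compound 2 (within the scatter), is within the scatter, so the two compounds cannot be separated on these data. That step concerns the group attached to the core, (3-(trifluoromethoxy)phenyl)amino in place of 4-methylpiperidin-1-yl on an aromatic carbon, and not the part of the molecule that is altered here.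

Compound 3, `CC1CCN(c2nc(Cl)nc3c2ncn3Cc2ccc(C(=O)Nc3ccccc3N)cc2)CC1`, differs from compound 1 as (2-aminophenyl)carbamoyl in place of 2-((2-aminophenyl)carbamoyl)ethenyl on an aromatic carbon. Within the data shown here, no measured step touches this position, so nothing in the data shows how this assay responds to losing the ethenyl link between the aromatic ring and the carbamoyl. Among the measured compounds shown here, the only guidance is that both measured compounds sit low in this assay and that the single known change left the number where it was, within the scatter. Compound 3 is therefore expected to stay in the same low region, with an expected step of a number 2.2 percentage points lower from compound 1 to compound 3 (within the scatter), not beyond the scatter. For compound 3 the estimate in this assay is 6%, ranging from -6% to 20%.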

Compound 3, a percentage reported as inhibition, at one concentration (the size of the read-out at that concentration, not a potency): 11.8%
Beside the measured number, compound 3's estimate is 5.8 percentage points below it; the measured number falls inside the stated range.
By their numbers in this assay, from the lowest: compounds 2, 1 and 3 (each within the scatter of the next).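

Within the data shown here, replacing 2-((2-aminophenyl)carbamoyl)ethenyl with (2-aminophenyl)carbamoyl, on an aromatic carbon para to a large group, gives the first reading at this position in this assay: a number 3.6 percentage points higher from compound 1 to compound 3 (within the scatter). On these data, the group without the ethenyl link cannot be told apart from the group that carries it, so compound 1 and compound 3 share the same low region at the single concentration tested. No evidence at hand bears on why the two compounds read alike.

The compounds shown leave open whether a saturated ethyl chain or a longer chain joining the aromatic ring to the carbamoyl, or a carboxylic acid in place of the (2-aminophenyl)carbamoyl, would give a number beyond the scatter of compound 1. Among these compounds, they also leave open whether losing the ethenyl link would read the same with the (3-(trifluoromethoxy)phenyl)amino group of compound 2 on the core instead of 4-methylpiperidin-1-yl, since the numbers so far all lie close together near the bottom of the scale.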